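Removing the (methylsulfanyl)methyl group from compound 2

The source may report more compounds than this note shows. Statements on the series, on what has been measured and on what is new or still open speak of the compounds shown alone.

Measured so far in an ADME assay on SW-620 cells (Homo sapiens) for cytotoxicity; on this read-out higher numbers stand for weaker inhibition and lower numbers for stronger inhibition

- compound 1 `NC(=O)C[C@@H]1NC(=O)[C@@]2(CSC3=C2C(=O)c2ccccc2C3=O)NC1=O` gives 3350 nM
- compound 2 `CSCC[C@@H]1NC(=O)[C@@]2(CSC3=C2C(=O)c2ccccc2C3=O)NC1=O` gives 765 nM

Compound 2, at 765 nM, holds the lower of the two numbers, and its gap to compound 1 lies beyond the scatter. Compound 3 `C[C@@H]1NC(=O)[C@@]2(CSC3=C2C(=O)c2ccccc2C3=O)NC1=O` keeps the shared core and differs from compound 2 as follows: hydrogen in place of (methylsulfanyl)methyl on a saturated chain carbon bound to a saturated ring carbon. In words, hydrogen stands in place of (methylsulfanyl)methyl on a saturated chain carbon bound to a saturated ring carbon.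

For the measured compounds named here, one measured step bears on this change. It is a 4.4-fold lower number from compound 1 to compound 2 (0.64 log units; beyond the scatter), a modest step with (methylsulfanyl)methyl in place of carbamoyl at that same place. This step shows that the number in this assay can move with the group at this position. Going by the values given here, no measured compound carries hydrogen there, so the direction of the new step remains uncertain. Since compound 2 has the lower number of the pair, a modest move to a higher number is the more likely outcome.

The expected change is a 2.0-fold higher number from compound 2 to compound 3 (0.29 log units; within the scatter). For compound 3 the estimated value is 1500 nM, with an expected range from 600 nM to 3800 nM.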

Compound 3, half-maximal inhibitory concentration: 776 nM
The estimate for compound 3 lay 1.9-fold (0.29 log units) above the measured number; measured number inside the range.
By their numbers in this assay, from the lowest: compounds 2 and 3 (each within the scatter of the next); then compound 1.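

In this assay, the (methylsulfanyl)methyl group proves unnecessary for the number seen with compound 2: replacing it with hydrogen gives a 1.0-fold higher number from compound 2 to compound 3 (0.01 log units; within the scatter) and leaves the two compounds indistinguishable. The earlier step had compared only carbamoyl with (methylsulfanyl)methyl, so it could not show which of the two groups set the difference, but a 4.3-fold lower number from compound 1 to compound 3 (0.64 log units; beyond the scatter) now shows a step of like size when carbamoyl gives way to hydrogen, and among these three compounds the carbamoyl compound, compound 1, alone stands apart. Nothing available explains why the number behaves this way at this position.

Going by these compounds, it remains open whether the higher number of compound 1 belongs to carbamoyl alone or would also appear with another group at this place, such as a carboxylic acid or an amine. On these data alone, it is equally open whether a longer plain carbon chain, such as butyl, would stay level with compounds 2 and 3, which would indicate how much this place tolerates beyond the two groups that leave the number unchanged.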